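Cytotoxicity notes: from compound 3 to compound 4

A few compounds are considered here, and "the series" means these few. Any claim that something is new, unique, unknown or untested is made for them only; others in the source may bear on it.

Measured so far:
compound 1, `FC(F)(F)c1cccc(NC(=S)Nc2ccc(Cl)cc2)c1`: 6800 nM
compound 2, `CC[C@H]1CC[C@H](c2ccc(NC(=S)Nc3cccc(C(F)(F)F)c3)cc2)CC1`: 39000 nM
compound 3, `CCOC(=O)c1ccc(NC(=S)Nc2cccc(C(F)(F)F)c2)cc1`: 23000 nM

All three share one core and differ only in the group on the aromatic carbon of the second ring. In an ADME assay on MT4 cells (Homo sapiens) for cytotoxicity (a lower number here means that less compound is tolerated, a higher number that more compound is tolerated), compound 3 gives 23000 nM, the second highest of the three numbers; its nearest neighbour is compound 2, a 1.7-fold lower number from compound 2 to compound 3 (0.23 log units; within the scatter), and the furthest is compound 1, a 3.4-fold higher number from compound 1 to compound 3 (0.53 log units; beyond the scatter).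

Compound 4, `O=[N+]([O-])c1ccc(NC(=S)Nc2cccc(C(F)(F)F)c2)cc1`, is the next member. It differs from compound 3 as follows: nitro in place of ethoxycarbonyl on an aromatic carbon. Nitro is not represented among the measured compounds, so no step bears on it directly. The steps available concern the same position: a 5.7-fold higher number from compound 1 to compound 2 (0.76 log units; beyond the scatter) and a 3.4-fold higher number from compound 1 to compound 3 (0.53 log units; beyond the scatter), both modest rises from the small chloro to the larger groups, while a 1.7-fold lower number from compound 2 to compound 3 (0.23 log units; within the scatter) is within the scatter. Nitro is closer in size to chloro than to ethoxycarbonyl, so the expectation in this assay is a modest step back toward compound 1 rather than a large one, with real uncertainty about whether it clears the scatter at all.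

For compound 4 the expected step is a 1.9-fold lower number from compound 3 to compound 4 (0.28 log units; within the scatter). The estimated value for compound 4 in this assay is 12000 nM, within a range from 4000 nM to 35000 nM.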

Compound 4, half-maximal cytotoxic concentration: 9200 nM
Compound 4: middle estimate off by 1.3-fold (0.12 log units), on the high side; measured number inside the range.
By their numbers in this assay, from the lowest: compounds 1 and 4 (each within the scatter of the next); then compounds 3 and 2 (each within the scatter of the next).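

In this assay, nitro in place of ethoxycarbonyl gives a 2.5-fold lower number from compound 3 to compound 4 (0.40 log units; beyond the scatter), so this position separates two groups that match in hydrogen-bond donors, hydrogen-bond acceptors and double bonds outside aromatic rings, and that differ in heavy atoms and in the elements they contain. Nitro also stands apart from 4-ethylcyclohexyl, with a 4.2-fold lower number from compound 2 to compound 4 (0.63 log units; beyond the scatter), but not from chloro, with a 1.4-fold higher number from compound 1 to compound 4 (0.13 log units; within the scatter), so the four groups now fall into two sets, chloro and nitro in one and ethoxycarbonyl and 4-ethylcyclohexyl in the other, with every step between the sets beyond the scatter. No measurement at hand bears on why the groups sort this way.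

Going by these compounds, four groups at one position are a thin basis, and it remains open whether an amine, a carboxylic acid or a longer ester chain would fall into either set or outside both. On these data alone, it is equally open whether the two sets would persist if the trifluoromethyl group elsewhere on the shared core gave way to a group such as chloro or methoxy.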